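Acid group swap on the compound 3 scaffold

This account rests on a few compounds, and the source may have more. Where it says the series, first, only, none or still open, it means among the compounds named here.

Measured in a functional assay (thoracic aorta) for inhibition, with Rattus norvegicus as the target; a lower number here means a stronger inhibitor, a higher number a weaker inhibitor:
- compound 1 `CC(C)c1ccc2c(CCCCCNS(=O)(=O)c3ccccc3)cc(C(=O)O)c-2cc1` gives 120 nM
- compound 2 `CC(C)c1cccc2c(CCCCCCCNS(=O)(=O)c3ccccc3)cc(C(=O)O)c-2c1` gives 930 nM
- compound 3 `CC(C)c1ccc2c(CCCCNS(=O)(=O)c3ccccc3)cc(CC(=O)O)c-2cc1` gives 300 nM

Compound 3 stands in the middle of this small set. Compound 3 at 300 nM has the second highest number of the three, above compound 1 and below compound 2, and both gaps lie beyond the scatter. The measured numbers run from compound 1 at 120 nM to compound 2 at 930 nM even though these compounds differ in more than one place. Going by the values given here, no pair of measured compounds differs in one place only, so the data hold no direct precedent for the next change.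

Compound 4 `CC(C)c1ccc2c(CCCCNS(=O)(=O)c3ccccc3)cc(S(=O)(=O)O)c-2cc1` has sulfo in place of carboxymethyl on an aromatic carbon. The rest of compound 3 is kept. Among the compounds with values here, with no matching step measured, no shift beyond the scatter is expected in this assay and the direction remains open, with a slightly lower number the tentative expectation. The expected result is a step of a 1.5-fold lower number from compound 3 to compound 4 (0.18 log units; within the scatter) that stays within the scatter. For compound 4 the estimated value is 200 nM with an expected range of 50 nM to 800 nM for this measurement.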

Compound 4, half-maximal inhibitory concentration: 17 nM
Compound 4: middle estimate off by 12-fold (1.07 log units), on the high side, and the stated range ends above it.
By their numbers in this assay, from the lowest: compound 4; then compound 1; then compound 3; then compound 2.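

In this assay, going by these compounds alone, the swap of carboxymethyl for sulfo gives an 18-fold lower number from compound 3 to compound 4 (1.25 log units; beyond the scatter), the first step that can be read at a single place, with the chain and the rest of compound 3 held fixed. Within the data shown here, this aromatic carbon of the five-membered aromatic ring, two ring bonds from the ring atom that bears a large group, is therefore sensitive to the identity of its substituent, something the earlier compounds, which differ in more than one place, could not show; the heavy-atom count is the same in both groups, so the step does not come with a larger substituent. Nothing measured here accounts for the size of this step.

Still open, going by these compounds, is whether the step belongs to the sulfur-based acid itself or to the removal of the carbon link between acid and ring, a question that a sulfomethyl or a phosphono group on the same aromatic carbon would help to settle. Also open, on these data alone, is whether the sulfo group gives a step of similar size on the longer chains of compound 1 and compound 2.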